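This account rests on a few compounds, and the source may have more. Where it says the series, first, only, none or still open, it means among the compounds named here.

Values in a functional assay on A549 cells (Homo sapiens) for inhibition, read by MTT assay, with a stated time of 72 h; on this read-out higher numbers stand for weaker inhibition and lower numbers for stronger inhibition:
- compound 1 `CC(C)(C)n1cc2c(n1)C(=O)CC1(CCN(C(=O)c3cc(-c4ccccc4)nc4ccccc34)CC1)O2`: 1940 nM
- compound 2 `CC(C)(C)n1cc2c(n1)C(=O)CC1(CCN(C(=O)c3cc(N4CCNCC4)nc4ccccc34)CC1)O2`: > 10000 nM. This value for compound 2 is a limit of the assay.
- compound 3 `CC(C)(C)n1cc2c(n1)C(=O)CC1(CCN(C(=O)c3cc(Cl)nc4ccccc34)CC1)O2`: 7170 nM

Among the measured compounds shown here, compound 3 has the higher of the only two actual numbers in this assay. The gap to the other is a 3.7-fold higher number from compound 1 to compound 3 (0.57 log units; beyond the scatter). Compound 2 cannot be ranked against compound 3, as the step of an at least 1.3-fold lower number from compound 2 to compound 3 (0.14 log units; that floor lies within the scatter) shows.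

Compound 4 `CCOc1cc(C(=O)N2CCC3(CC2)CC(=O)c2nn(C(C)(C)C)cc2O3)c2ccccc2n1` has ethoxy in place of chloro on an aromatic carbon next to the ring nitrogen: ethoxy in place of chloro on an aromatic carbon. The measured steps all vary this same carbon. Both of the steps away from phenyl raise the number: a 3.7-fold higher number from compound 1 to compound 3 (0.57 log units; beyond the scatter) for chloro and an at least 5.1-fold higher number from compound 1 to compound 2 (0.71 log units; beyond the scatter) for piperazin-1-yl. For the measured compounds named here, none of them involves ethoxy, so they give the scale of change at this carbon but no direct precedent for the new group. Compound 1 at 1940 nM marks a plausible lower end, and this assay stops giving numbers not far above compound 3 at 7170 nM. A small change within the scatter is therefore expected, with only a slight lean towards a lower number.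

The expected change is a 1.3-fold lower number from compound 3 to compound 4 (0.12 log units; within the scatter). For compound 4 the estimate is 5500 nM, with an expected range of 2000 nM to 12000 nM.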

Compound 4, half-maximal inhibitory concentration: > 10000 nM
Compound 4 was reported as a limit; the forecaster's own chance of this, stated with the estimate: 20%; middle value at least 1.8-fold (0.25 log units) from the limit.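

In this assay compound 4 gives > 10000 nM, which is a limit of the assay. Ethoxy now joins chloro and piperazin-1-yl as a third replacement of phenyl on this aromatic carbon next to the ring nitrogen that raises the number, with an at least 5.1-fold higher number from compound 1 to compound 4 (0.71 log units; beyond the scatter), and none of the compounds shown goes against this pattern. Against chloro the result is an at least 1.3-fold higher number from compound 3 to compound 4 (0.14 log units; that floor lies within the scatter), so ethoxy cannot be separated from chloro, the step between compound 2 and compound 4 cannot be read, and the weak end of the series at this carbon has no readable order: the limit of > 10000 nM in this assay, at which 2 of the 4 values shown sit.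

As far as these compounds go, only phenyl stands for an aromatic ring at this carbon, so it stays open whether the lower number of compound 1 belongs to phenyl alone or would carry over to a pyridyl or a substituted phenyl group. From the compounds shown here alone, it also stays open whether a small alkyl group such as methyl would give a readable number in this assay and so show how much of the step from phenyl depends on an aromatic ring at this carbon.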